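The source may hold more compounds than are shown below. What is called first, only, known or untested is meant among the compounds shown, and "the series" means these compounds.

Measured so far in a functional assay on LNCaP cells (Homo sapiens) for cytotoxicity, read by MTT assay, with a stated time of 72 h; a higher number here means a weaker inhibitor, a lower number a stronger inhibitor:
Compound 1 `CC1=C(/C=C/C(=O)/C=C/c2cccc(C(F)(F)F)c2)C(C)(C)CCC1` gives 2800 nM.
Compound 2 `CC1=C(/C=C/C(=O)/C=C/c2cc(C(F)(F)F)cc(C(F)(F)F)c2)C(C)(C)CCC1` gives 8700 nM.
Compound 3 `CC1=CCCC(C)(C)C1/C=C/C(=O)/C=C/c1ccccc1F` gives 1600 nM.

Compound 1 and compound 2 differ by trifluoromethyl in place of hydrogen on an aromatic carbon, and this gave a 3.1-fold higher number from compound 1 to compound 2 (0.49 log units; beyond the scatter). Compound 4 `CC1=CCCC(C)(C)C1/C=C/C(=O)/C=C/c1cc(C(F)(F)F)ccc1F` has not yet been measured in this assay; it differs from compound 3 by trifluoromethyl in place of hydrogen on an aromatic carbon. The surroundings are not identical: in compound 2 the entering group is meta to a trifluoromethyl group, while in compound 4 it is para to a fluoro group, so this is the same kind of change, not the same change. The difference between the core of compound 3 and the core of compound 1 is not broken down here. Compound 3 and compound 1 lie within the usual scatter of each other. The expectation rests on a 3.1-fold higher number from compound 1 to compound 2 (0.49 log units; beyond the scatter), with the caveat that the surroundings differ. Compound 4 is expected to show a 2.8-fold higher number from compound 3 to compound 4 (0.45 log units; beyond the scatter). Compound 4 is estimated at 4500 nM, most likely between 1800 nM and 11000 nM.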

Compound 4, half-maximal inhibitory concentration: 1700 nM
Beside the measured number, compound 4's estimate is 2.6-fold (0.42 log units) above it; measured number outside the range, below it.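

In this assay, trifluoromethyl in place of hydrogen on an aromatic carbon gives a 1.1-fold higher number from compound 3 to compound 4 (0.03 log units; within the scatter). The same kind of change therefore did not carry the same size of step from one core to the other: the same change on two cores in this assay, a 3.1-fold higher number (0.49 log units; beyond the scatter) from compound 1 to compound 2 and a 1.1-fold higher number (0.03 log units; within the scatter) from compound 3 to compound 4, 2.9-fold (0.47 log units) apart, beyond the scatter of two such steps. This shows that the step seen on one core did not predict the step on the other, but it does not show whether the core or the neighbouring group accounts for the gap, and two pairs give no general rule.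

The compounds shown leave open how the step would look on further cores. They also leave open how a methoxy group or an amine would behave in place of trifluoromethyl, para to a fluoro group.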